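Lengthening the Piperidine Chain of Compound 3

The source may hold more compounds than are shown below. What is called first, only, known or untested is meant among the compounds shown, and "the series" means these compounds.

Within the data shown here, compound 3 (`O=c1oc2cc(O)ccc2c(-c2ccc(OCCCCN3CCCCC3)cc2)c1-c1ccccc1`) gives 134 nM in a functional assay on MCF7 cells (Homo sapiens) for antiproliferative activity (a lower number here means a stronger inhibitor, a higher number a weaker inhibitor), the highest of the three numbers so far. Compound 4 (`O=c1oc2cc(O)ccc2c(-c2ccc(OCCCCCCN3CCCCC3)cc2)c1-c1ccccc1`) has not yet been measured. Compared with compound 3, it carries 2-(piperidin-1-yl)ethyl in place of piperidin-1-yl on a saturated chain carbon, four bonds along the chain from an oxygen on an aromatic ring, on a saturated chain carbon, four bonds along the chain from an oxygen on an aromatic ring. Among the measured compounds shown here, no measured pair differs in one place only, so the expectation rests loosely on compound 1 (`O=c1oc2cc(O)ccc2c(-c2cccc(OCCCCCN3CCCCC3)c2)c1-c1ccccc1`) at 15 nM and compound 2 (`O=c1oc2cc(O)ccc2c(Cc2ccc(OCCCN3CCCCC3)cc2)c1-c1ccccc1`) at 18 nM, both lower than compound 3 beyond the scatter. A moderate fall in this assay is therefore expected, an estimated 3.0-fold lower number from compound 3 to compound 4 (0.47 log units; beyond the scatter). Compound 4 is estimated at 45 nM, with an expected range of 12 nM to 160 nM.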

Compound 4, half-maximal inhibitory concentration: 720 nM
Beside the measured number, compound 4's estimate is 16-fold (1.20 log units) below it; the measured number lies above the stated range.
By their numbers in this assay, from the lowest: compounds 1 and 2 (each within the scatter of the next); then compound 3; then compound 4.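

In this assay, among these compounds, 2-(piperidin-1-yl)ethyl in place of piperidin-1-yl on a saturated chain carbon, four bonds along the chain from an oxygen on an aromatic ring, gives a 5.4-fold higher number from compound 3 to compound 4 (0.73 log units; beyond the scatter) and gives the first reading of a single change. At this position, the longer chain goes with a weaker inhibitor, a direction that compounds differing in more than one place could not show. Nothing shown accounts for this rise.

On these data alone, whether a shorter chain at this position would give a lower number remains open. So does the effect of a pyrrolidine or a dimethylamino group in place of the piperidine ring.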